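Isobutyl for isopropyl on the shared core

A few compounds are considered here, and "the series" means these few. Any claim that something is new, unique, unknown or untested is made for them only; others in the source may bear on it.

Compound 1 `CCc1c(C(=O)OC)[nH]c2cc(OC)ccc12`: > 100000 nM
Compound 2 `COC(=O)c1[nH]c2cc(OC)ccc2c1C(C)C`: 81500 nM

All values come from a functional assay on RS4-11 cells (Homo sapiens) for antiproliferative activity, read by MTT assay, with a stated time of 48 h; a higher number here means that more compound is needed for the effect, a lower number that less compound is needed. The entry for compound 1 is a limit of the assay and not a number. In this assay, among the measured compounds shown here, compound 2 gives 81500 nM, the only actual number so far, so it has no measured number to be ranked against.

Compound 3 `COC(=O)c1[nH]c2cc(OC)ccc2c1CC(C)C` carries isobutyl in place of isopropyl on an aromatic carbon, next to the ring atom that bears a methoxycarbonyl group: isobutyl in place of isopropyl on an aromatic carbon.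

For the measured compounds named here, one measured step bears on this change, a methyl added to the same chain: an at least 1.2-fold lower number from compound 1 to compound 2 (0.08 log units; that floor lies within the scatter). Going by the values given here, with only that step from compound 1 as a guide, no change beyond the scatter is expected in this assay, and no direction can be favoured. The expected change is a 1.0-fold lower number from compound 2 to compound 3 (0.01 log units; within the scatter). For compound 3 the estimated value is 80000 nM, with an expected range of 30000 nM to 200000 nM.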

Compound 3, half-maximal effective concentration: 37800 nM
Compound 3: middle estimate off by 2.1-fold (0.33 log units), on the high side; measured number inside the range.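

In this assay, among the compounds shown here, isobutyl in place of isopropyl on this aromatic carbon gives a 2.2-fold lower number from compound 2 to compound 3 (0.33 log units; beyond the scatter), the first step between two actual numbers and one that lies beyond the scatter. The series therefore accepts the larger chain at this position, two ring bonds from the ring nitrogen, and the number falls with it, although compound 3 is only modestly ahead of compound 2. The other new step, an at least 2.6-fold lower number from compound 1 to compound 3 (0.42 log units; beyond the scatter), gives a floor and not a size, since the entry for compound 1 is a limit of the assay: the limit of > 100000 nM in this assay, at which 1 of the 3 values shown sits.

From the compounds shown here alone, whether the number keeps falling with a longer chain such as hexyl, or with a benzyl group, stays open. Also open, going by these compounds, is whether the methoxycarbonyl group matters, which a carboxylic acid or an amide in its place would test.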